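Adding two methyl groups to the sulfonamide phenyl

This account rests on a few compounds, and the source may have more. Where it says the series, first, only, none or still open, it means among the compounds named here.

Compound 1 `CCCCc1ccc(NS(=O)(=O)c2ccc(N3CCNC3=O)cc2)cc1`: 770 nM
Compound 2 `O=C1NCCN1c1ccc(S(=O)(=O)Nc2ccccc2)cc1`: 470 nM
Compound 3 `CCCCOc1ccc(NS(=O)(=O)c2ccc(N3CCNC3=O)cc2)cc1`: 870 nM

These three numbers come from a functional assay on MCF7 cells (Homo sapiens) for antiproliferative activity, read by sulforhodamine B assay, with a stated time of 48 h; a higher number here means a weaker inhibitor, a lower number a stronger inhibitor. Compound 2 carries a plain phenyl on the sulfonamide nitrogen, and its value of 470 nM lies within the scatter of the values of both other compounds, so the three stand level.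

Within the data shown here, compound 4 `Cc1cccc(NS(=O)(=O)c2ccc(N3CCNC3=O)cc2)c1C` keeps the shared core and alters only that group: 2,3-dimethylphenyl in place of phenyl on a sulfonamide nitrogen. Two measured steps change the same phenyl: a 1.6-fold lower number from compound 1 to compound 2 (0.21 log units; within the scatter) and a 1.9-fold higher number from compound 2 to compound 3 (0.27 log units; within the scatter). Both are small, and neither goes beyond the scatter. Neither involves methyl groups, however, so they offer only indirect guidance, and the estimate is correspondingly uncertain.

No change beyond the scatter is expected in this assay, and the estimated step is a 1.3-fold higher number from compound 2 to compound 4 (0.11 log units; within the scatter). For compound 4 the expected value is 600 nM, with an estimated range from 220 nM to 1600 nM.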

Compound 4, half-maximal inhibitory concentration: 230 nM
Beside the measured number, compound 4's estimate is 2.6-fold (0.42 log units) above it; low and high end bracket the measured number.
By their numbers in this assay, from the lowest: compound 4; then compounds 2, 1 and 3 (each within the scatter of the next).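

In this assay, 2,3-dimethylphenyl in place of phenyl on a sulfonamide nitrogen gives a 2.0-fold lower number from compound 2 to compound 4 (0.31 log units; beyond the scatter), the only step among these compounds that lies beyond the scatter, though it is modest in size. The group on this nitrogen can therefore move the number, something the butyl and butoxy compounds, which stand level with the plain phenyl of compound 2, did not show. No measurement here explains why the two methyl groups have this effect.

The compounds shown leave open whether a single methyl group would do the same, as 2-methylphenyl and 3-methylphenyl do not appear among them. Also open, from the compounds shown here alone, is how this phenyl would respond to a different kind of group, such as a chlorine, an amine or a carboxylic acid.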